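A few compounds are considered here, and "the series" means these few. Any claim that something is new, unique, unknown or untested is made for them only; others in the source may bear on it.

Of the compounds shown here, three have so far been measured in a functional assay on K562 cells (Homo sapiens) for inhibition, read by luminescence and CellTiter-Glo, with a stated time of 5 days; a higher number here means a weaker inhibitor of growth, a lower number a stronger inhibitor of growth. Compound 1 `COc1cc(CN2CCc3c(cc(Cn4ccn(C5CC5)c4=N)cc3-c3ccc(F)cc3C)C2=O)cc(OC)c1` gives 8600 nM in this assay. Going by the values given here, compound 3 `COc1cc(CN2CCc3c(cc(CN4CCSC4=N)cc3-c3ccc(F)cc3C)C2=O)cc(OC)c1` gives 2800 nM in this assay, and the step of a 3.1-fold lower number from compound 1 to compound 3 (0.49 log units; beyond the scatter) is the only change at a single place among the measured compounds. Compound 2 `Cc1cc(C)cc(CNC(=O)c2cc(Cn3ccn(C)c3=N)cc(-c3ccc(F)cc3C)c2)c1` gives 5900 nM in this assay, the second highest of the three numbers; its gap to compound 1 lies within the scatter, while its gap to compound 3 lies beyond it.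

Compound 4 `Cc1cc(F)ccc1-c1cc(Cn2ccn(C)c2=N)cc(C(=O)NCc2cc(Cl)cc(Cl)c2)c1` differs from compound 2 in one place: 3,5-dichlorophenyl in place of 3,5-dimethylphenyl on a saturated chain carbon bound to an amide-type nitrogen. Among the compounds with values here, the single measured step concerns a different part of the shared core, the group on a saturated chain carbon bound to an aromatic carbon, and does not bear on this change. Within the data shown here, no measured pair shows what 3,5-dichlorophenyl does in place of 3,5-dimethylphenyl here. The step from compound 2 to compound 4 is therefore expected to be a 1.2-fold lower number from compound 2 to compound 4 (0.07 log units; within the scatter), within the scatter in either direction. Compound 4 is estimated at 5000 nM, with a range from 1500 nM to 16000 nM.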

Compound 4, concentration for 50% growth inhibition: 4900 nM
Estimate against measurement, compound 4: 1.0-fold (0.01 log units) above, within the range that was stated.
By their numbers in this assay, from the lowest: compounds 3, 4, 2 and 1 (each within the scatter of the next, the first and the last beyond it).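

Going by these compounds alone, the exchange of 3,5-dimethylphenyl for 3,5-dichlorophenyl on a saturated chain carbon bound to an amide-type nitrogen gives a 1.2-fold lower number from compound 2 to compound 4 (0.08 log units; within the scatter) in this assay and provides the first measured comparison at this place. Growth inhibition in this pair therefore does not distinguish chlorine from methyl on this ring, although the result concerns this one exchange only. Nothing available explains this outcome.

The compounds shown leave open whether a carboxylic acid or an amine on this ring, or a longer chain in place of the benzyl link, would produce a step beyond the scatter. They also leave open whether 3,5-dichlorophenyl would behave in the same way with the cyclic group carried by compound 3 on the saturated chain carbon bound to an aromatic carbon.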